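This account rests on a few compounds, and the source may have more. Where it says the series, first, only, none or still open, it means among the compounds named here.

Of the compounds shown here, three on a shared core have been measured so far in a functional assay on HepG2 cells (Homo sapiens) for inhibition, read by MTT assay, with a stated time of 48 h; a lower number here means a stronger inhibitor, a higher number a weaker inhibitor. Compound 1 (`Cc1nc(N(C)c2ccc([Se]C#N)c(C)c2)c2ccccc2n1`) gives 9 nM there, and compound 2 (`Cc1nc(N(C)c2ccc([Se]C#N)c(Cl)c2)c2ccccc2n1`) gives 12 nM there. Compound 3 (`C[Se]c1ccc(N(C)c2nc(C)nc3ccccc23)cc1Cl`) gives 4 nM and holds the lowest of the three numbers, beyond the scatter from both others.

The compound still unmeasured, compound 4 (`C[Se]c1ccc(N(C)c2nc(C)nc3ccccc23)cc1C`), differs from compound 3 by a single change: methyl in place of chloro on an aromatic carbon, ortho to a group of 2 heavy atoms and meta to a large group (methyl in place of chloro on an aromatic carbon).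

Within the data shown here, the closest precedent is a 1.3-fold higher number from compound 1 to compound 2 (0.12 log units; within the scatter) which exchanges the same two groups in the opposite sense, chloro in place of methyl on an aromatic carbon. Among the measured compounds shown here, that step stays within the scatter, but it was measured with cyano on the selenium, and no such pair with methyl on the selenium exists yet. The other measured step, a 3.0-fold lower number from compound 2 to compound 3 (0.48 log units; beyond the scatter) is modest and concerns methyl in place of cyano on a selenium, a place that stays unchanged here.

No shift beyond the scatter is therefore expected in this assay. The estimated step is a 1.1-fold lower number from compound 3 to compound 4 (0.06 log units; within the scatter) and it is expected to stay small. Compound 4 is estimated at 3.5 nM (expected range 1.5 nM to 8 nM).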

Compound 4, half-maximal inhibitory concentration: 6 nM
Beside the measured number, compound 4's estimate is 1.7-fold (0.23 log units) below it; low and high end bracket the measured number.
By their numbers in this assay, from the lowest: compounds 3, 4, 1 and 2 (each within the scatter of the next, the first and the last beyond it).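

Compound 4 supplies the missing pair: with methyl on the selenium, the exchange of chloro and methyl on this aromatic carbon in this assay gives a small step (a 1.5-fold higher number from compound 3 to compound 4 (0.18 log units; within the scatter)), so this change has now been read with both selenium groups and stays within the scatter each time. The two readings also agree with each other: (the same change on two cores in this assay, a 1.3-fold higher number (0.12 log units; within the scatter) from compound 1 to compound 2 and a 1.5-fold lower number (0.18 log units; within the scatter) from compound 4 to compound 3, 2.0-fold (0.30 log units) apart, within the scatter of two such steps). Compound 4 further gives a second reading of the change on the selenium (a 1.5-fold lower number from compound 1 to compound 4 (0.18 log units; within the scatter)), which stays within the scatter whereas the earlier reading (a 3.0-fold lower number from compound 2 to compound 3 (0.48 log units; beyond the scatter)) lay beyond it, yet the two steps cannot be told apart: (the same change on two cores in this assay, a 3.0-fold lower number (0.48 log units; beyond the scatter) from compound 2 to compound 3 and a 1.5-fold lower number (0.18 log units; within the scatter) from compound 1 to compound 4, 2.0-fold (0.30 log units) apart, within the scatter of two such steps).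

The compounds shown place only chloro and methyl on this aromatic carbon, so it remains open whether the numbers would stay this close with an amine, a carboxylic acid or a longer chain there. On the selenium, only methyl and cyano appear, which leaves open how a longer chain at that place would read in this assay and whether it would depend on the group on the aromatic carbon.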